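Swapping Methoxy for Methylsulfonyl on the Benzylamide

The source may hold more compounds than are shown below. What is called first, only, known or untested is meant among the compounds shown, and "the series" means these compounds.

Three compounds share one core and differ only in the group on the far aromatic ring. Compound 1 `CC(C)(C)c1ccc(C(=O)NCc2ccc(SC(F)(F)F)cc2)cc1` gives 0.4 nM in an assay on HeLa cells with Bile acid receptor (Homo sapiens) as the target, read by a luciferase reporter, with a stated time of 24 h; a lower number here means that less compound is needed, a higher number that more compound is needed for the effect. Compound 2 `CC(C)(C)c1ccc(C(=O)NCc2ccc(C(N)=O)cc2)cc1` gives 3800 nM. Compound 3 `COc1ccc(CNC(=O)c2ccc(C(C)(C)C)cc2)cc1` gives 150 nM, the second highest of the three numbers: a 380-fold higher number from compound 1 to compound 3 (2.57 log units; beyond the scatter), while a 25-fold lower number from compound 2 to compound 3 (1.40 log units; beyond the scatter). The next compound, compound 4 `CC(C)(C)c1ccc(C(=O)NCc2ccc(S(C)(=O)=O)cc2)cc1`, carries methylsulfonyl in place of methoxy on an aromatic carbon. Going by the values given here, two measured steps bear on this change. Compound 2, whose carbamoyl also brings more than one hydrogen-bond acceptor to this position, stands far above compound 3, since a 25-fold lower number from compound 2 to compound 3 (1.40 log units; beyond the scatter); and the step of a 9500-fold higher number from compound 1 to compound 2 (3.98 log units; beyond the scatter) shows how far this position can move the number. Because compound 2 sits at 3800 nM, a rise from compound 3 to compound 4 is expected rather than a fall. The estimated step is a 20-fold higher number from compound 3 to compound 4 (1.30 log units; beyond the scatter). Compound 4 is therefore expected to give about 3000 nM, with a range from 500 nM to 15000 nM.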

Compound 4, half-maximal effective concentration: 3800 nM
Estimate against measurement, compound 4: 1.3-fold (0.10 log units) below; the range from low to high includes it.
By their numbers in this assay, from the lowest: compound 1; then compound 3; then compounds 2 and 4 (each within the scatter of the next).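

Methylsulfonyl and carbamoyl are different groups, yet they give the same printed result at this position (no change at the digits printed from compound 2 to compound 4 (within the scatter)), and the change from methoxy to methylsulfonyl is a large one (a 25-fold higher number from compound 3 to compound 4 (1.40 log units; beyond the scatter)). Sulfur alone does not secure a low number, since both compounds carry it in their groups and (trifluoromethyl)sulfanyl stands far from methylsulfonyl (a 9500-fold higher number from compound 1 to compound 4 (3.98 log units; beyond the scatter)). No measurement available here explains why methylsulfonyl and carbamoyl match or why the sulfur groups differ so widely.

Going by these compounds, it remains open whether an amine or a carboxylic acid on this aromatic carbon would give a number close to that of compound 4. It is also unknown where trifluoromethyl, without the sulfur, or ethylsulfonyl, with its longer chain, would fall relative to compound 1 and compound 4.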